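Replacing the Side Chain on the Carbonyl of Compound 1

The compounds below may be only part of what the source reports. "The series", "measured", "known", "first", "only" and "open" are said of these compounds alone.

Going by the values given here, in a functional assay on PANC-1 cells (Homo sapiens) for antiproliferative activity, read by MTT assay, with a stated time of 48 h (a higher number here means a weaker inhibitor, a lower number a stronger inhibitor), compound 1 (`Cc1c(C(=O)NCCCN(C)C)oc2ccc(N(Cc3ccc(Br)cc3)S(=O)(=O)c3ccc(Br)cc3)cc12`) gives 2300 nM, the lowest of the three numbers measured so far. Compound 2 (`Cc1c(C(=O)OCCCN(C)C)oc2ccc(N(Cc3ccc(Br)cc3)S(=O)(=O)c3ccc(Br)cc3)cc12`) gives 24600 nM, and compound 3 (`Cc1c(C(=O)NCC(O)CO)oc2ccc(N(Cc3ccc(Br)cc3)S(=O)(=O)c3ccc(Br)cc3)cc12`) gives 29300 nM. These two values sit within the scatter of each other, as a 1.2-fold higher number from compound 2 to compound 3 (0.08 log units; within the scatter) shows.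

Compound 4 (`Cc1c(C(=O)N2CCCC(C)C2)oc2ccc(N(Cc3ccc(Br)cc3)S(=O)(=O)c3ccc(Br)cc3)cc12`) carries 3-methylpiperidin-1-yl in place of (3-(dimethylamino)propyl)amino on a carbonyl carbon. Among the compounds with values here, two measured steps bear on this change, as each alters the same side chain of compound 1 and each is large: an 11-fold higher number from compound 1 to compound 2 (1.03 log units; beyond the scatter), and a 13-fold higher number from compound 1 to compound 3 (1.11 log units; beyond the scatter). Neither step tests this ring, so the comparison is only indirect. A large rise of similar size is therefore expected, and the estimated step is a 6.1-fold higher number from compound 1 to compound 4 (0.78 log units; beyond the scatter). For compound 4, the estimated value is 14000 nM, with an expected range of 5000 nM to 40000 nM.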

Compound 4, half-maximal inhibitory concentration: 26200 nM
Compound 4: middle estimate off by 1.9-fold (0.27 log units), on the low side; low and high end bracket the measured number.
By their numbers in this assay, from the lowest: compound 1; then compounds 2, 4 and 3 (each within the scatter of the next).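

The ring carried by compound 4 costs as much as either earlier change in this assay (an 11-fold higher number from compound 1 to compound 4 (1.06 log units; beyond the scatter)), so the loss on this carbonyl carbon is not confined to swapping the amide nitrogen for oxygen or to replacing the dimethylamino group with hydroxyl groups. Compound 4 lacks both the amide hydrogen and the dimethylamino group, yet it stands level with compound 2, which lacks only the first (a 1.1-fold higher number from compound 2 to compound 4 (0.03 log units; within the scatter)), and with compound 3, which lacks only the second (a 1.1-fold lower number from compound 3 to compound 4 (0.05 log units; within the scatter)). Among these compounds, only compound 1 keeps both features and reaches the low number. Nothing given here explains this pattern.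

On these data alone, whether a 4-methylpiperazin-1-yl ring, which places a tertiary amine on the carbonyl without an amide hydrogen, would recover the number of compound 1 remains open. So does the effect of a shorter or longer chain between the amide nitrogen and the dimethylamino group.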